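Replacing a methoxyphenyl with a cyanophenyl: an untested step

A few compounds are considered here, and "the series" means these few. Any claim that something is new, unique, unknown or untested is made for them only; others in the source may bear on it.

Compound 1 `Cc1ccccc1Cc1cnc(CCc2ccc(-c3ccccc3C(=O)O)cc2)[nH]1`: 127 nM
Compound 2 `O=C(O)c1ccccc1-c1ccc(CCc2ncc(CC3CCCC3)[nH]2)cc1`: 133 nM
Compound 3 `COc1cccc(Cc2cnc(CCc3ccc(-c4ccccc4C(=O)O)cc3)[nH]2)c1`: 4120 nM

In an in vitro functional assay on cells for agonist activity at Bombesin receptor subtype-3 (Homo sapiens), read by luminescence and calcium flux (a higher number here means that more compound is needed for the effect, a lower number that less compound is needed), compound 3 gives the highest number of the three, with both other compounds well separated from it. Compound 4 `N#Cc1ccc(Cc2cnc(CCc3ccc(-c4ccccc4C(=O)O)cc3)[nH]2)cc1` differs from compound 3 in one place: 4-cyanophenyl in place of 3-methoxyphenyl on a saturated chain carbon bound to an aromatic carbon. Within the data shown here, no measured step makes this exact change. The two steps that lead into compound 3 show how strongly the 3-methoxyphenyl raised the number: a 32-fold higher number from compound 1 to compound 3 (1.51 log units; beyond the scatter) and a 31-fold higher number from compound 2 to compound 3 (1.49 log units; beyond the scatter). Nothing measured carries a 4-cyanophenyl, so whether it recovers that loss is open. A moderate fall in the number is expected, with wide uncertainty. For compound 4 the estimate in this assay is 1500 nM, ranging from 300 nM to 8000 nM, an expected step of a 2.7-fold lower number from compound 3 to compound 4 (0.44 log units; beyond the scatter).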

Compound 4, half-maximal effective concentration: 5890 nM
For compound 4 the middle estimate is 3.9-fold (0.59 log units) below the measured one, within the range that was stated.
By their numbers in this assay, from the lowest: compounds 1 and 2 (each within the scatter of the next); then compounds 3 and 4 (each within the scatter of the next).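

In this assay, 4-cyanophenyl on this saturated chain carbon does not recover the loss seen with 3-methoxyphenyl: a 1.4-fold higher number from compound 3 to compound 4 (0.16 log units; within the scatter). Compound 4 stays far from the two low-number compounds, with a 44-fold higher number from compound 2 to compound 4 (1.65 log units; beyond the scatter) and a 46-fold higher number from compound 1 to compound 4 (1.67 log units; beyond the scatter), so this high number is not peculiar to 3-methoxyphenyl, although the 2-methylphenyl of compound 1 shows that not every substituted phenyl gives it. Nothing available explains why these groups differ so much. The compounds shown leave open whether a plain phenyl or a longer saturated chain at this place would give a number nearer that of compound 1 or compound 4.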